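Adding a Methoxy Group to a Swim-Test Compound with a Low Number

A few compounds are considered here, and "the series" means these few. Any claim that something is new, unique, unknown or untested is made for them only; others in the source may bear on it.

Compound 1, `COc1ccc(-c2cc3cc(C4C(C#N)=C(N)OC5=C4C(=O)CC(C)(C)C5)cc(C(C)C)c3oc2=O)cc1`: 64.9%
Compound 2, `COc1ccc(-c2cc3cc(C4C(C#N)=C(N)OC5=C4C(=O)CC(C)(C)C5)cc(C)c3oc2=O)cc1OC`: 10.4%

In a functional assay on the whole organism (strain Swiss albino) with Mus musculus as the target, in the forced swim test, with a stated time of 5 min, at a dose of 0.5 mg/kg by the intraperitoneal route (a lower number here means less inhibition, a higher number more inhibition at the dose given (going by the name of the read-out)), compound 2 gives 10.4%, the lowest of the two numbers; compound 1 gives 64.9%, a gap beyond the usual scatter. Compound 3, `COc1cc(-c2cc3cc(C4C(C#N)=C(N)OC5=C4C(=O)CC(C)(C)C5)cc(C)c3oc2=O)cc(OC)c1OC`, differs from compound 2 by methoxy in place of hydrogen on an aromatic carbon. Going by the values given here, no measured pair with a comparable change exists here, so the size of the step is open; a modest rise, if any, seems the most plausible outcome. Compound 3 is expected to give 20%, with a range from 5% to 45%. That estimate means an expected step of a number 9.6 percentage points higher from compound 2 to compound 3 (within the scatter), small and not clearly beyond the scatter.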

Compound 3, a percentage reported as inhibition, in the whole organism at one dose (the size of the read-out at that dose, not a potency): 6.37%
Compound 3: the middle estimate sits 13.6 percentage points above what was measured; the measured number falls inside the stated range.
By their numbers in this assay, from the lowest: compounds 3 and 2 (each within the scatter of the next); then compound 1.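

In this assay, going by these compounds alone, replacing the 3,4-dimethoxyphenyl with the 3,4,5-trimethoxyphenyl gives a number 4 percentage points lower from compound 2 to compound 3 (within the scatter) as the first step between compounds that differ in one place. At this aromatic carbon, then, methoxy in place of hydrogen produces no change that can be told from the scatter at this single dose. No information on hand bears on why the number holds steady.

Going by these compounds, whether an amine or a carboxylic acid on this same carbon would move the number remains open. So does whether a longer chain, such as ethoxy, would do so.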